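Fluoro for chloro on the 2,4-dichlorobenzyl group

The source may report more compounds than this note shows. Statements on the series, on what has been measured and on what is new or still open speak of the compounds shown alone.

In a functional assay on MCF cells (Homo sapiens) for antiproliferative activity, with a stated time of 72 h (a lower number here means a stronger inhibitor, a higher number a weaker inhibitor), two compounds sharing one core have been tested so far. Compound 1 `COc1ccccc1CNc1ncnc2c1ncn2[C@@H]1O[C@H](CO)[C@@H](O)[C@H]1O` gives only a limit, > 166000 nM, and no number. Among the compounds with values here, compound 2 `OC[C@H]1O[C@@H](n2cnc3c(NCc4ccc(Cl)cc4Cl)ncnc32)[C@H](O)[C@@H]1O`, which carries a 2,4-dichlorobenzyl group, gives 127000 nM, the only actual number available. Compound 3 `OC[C@H]1O[C@@H](n2cnc3c(NCc4ccc(F)cc4Cl)ncnc32)[C@H](O)[C@@H]1O` differs from compound 2 in a single substituent: fluoro in place of chloro on an aromatic carbon. Fluoro in place of chloro on an aromatic carbon thus turns 2,4-dichlorobenzyl into 2-chloro-4-fluorobenzyl, a change not yet measured on this core. Within the data shown here, the one measured step, an at least 1.3-fold lower number from compound 1 to compound 2 (0.11 log units; that floor lies within the scatter), puts 2,4-dichlorophenyl in place of 2-methoxyphenyl, and with its floor within the scatter it gives no ground to expect a sizeable move from the smaller swap in compound 3. No change beyond the scatter is therefore expected, and the expected step is a 1.1-fold higher number from compound 2 to compound 3 (0.03 log units; within the scatter). For compound 3 the estimated value is 135000 nM, with an expected range from 65000 nM to 230000 nM.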

Compound 3, half-maximal inhibitory concentration: > 166000 nM
Compound 3 ended at the assay's limit; the forecaster's own chance of this, stated with the estimate: 30%; middle value at least 1.2-fold (0.08 log units) from the limit.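

In this assay, fluoro in place of chloro on this aromatic carbon, para to a large group, gives an at least 1.3-fold higher number from compound 2 to compound 3 (0.11 log units; that floor lies within the scatter). Within the data shown here, this is the first look at this position alone, and it shows no gain from fluoro: compound 3 gives a limit and not a number, so compound 2 remains the only compound of the three with an actual value, and the size of the change cannot be fixed beyond that floor, which lies within the scatter. The step between compound 1 and compound 3 cannot be read, because both values are limits, so the 2-chloro-4-fluorophenyl and 2-methoxyphenyl groups cannot be ordered: the limit of > 166000 nM in this assay, at which 2 of the 3 values shown sit.

The compounds shown leave open how far compound 3 actually lies from compound 2, and so whether replacing chloro with fluoro here matters at all. They also leave open whether a different group at this position, such as an amine, a carboxylic acid or a longer chain, would give a number clearly lower than that of compound 2 in this assay.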